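This account rests on a few compounds, and the source may have more. Where it says the series, first, only, none or still open, it means among the compounds named here.

Series notes, cytotoxicity on rat myoblasts.

Of the compounds shown here, three on a shared core have been measured in an ADME assay on L6 cells (Rattus norvegicus) for cytotoxicity, read by resazurin assay, with a stated time of 72 h; on this read-out higher numbers stand for an effect only at larger amounts of compound and lower numbers for an effect already at smaller amounts. Compound 1 `CCOC(=O)C1=C(C)N/C(=C/c2cc(C)n(-c3ccc(CN(C)C)cc3)c2C)C1=O` gives 120000 nM. Compound 2 `CCOC(=O)C1=C(C)N/C(=C/c2cc(C)n(-c3ccc(N(C)C)cc3)c2C)C1=O` gives 180000 nM. Compound 3 `CCOC(=O)C1=C(C)N/C(=C/c2cc(C)n(-c3ccc(SC(F)(F)F)cc3)c2C)C1=O` gives 140000 nM. The three numbers sit close together: the step of a 1.2-fold higher number from compound 1 to compound 3 (0.07 log units; within the scatter) and the step of a 1.3-fold lower number from compound 2 to compound 3 (0.11 log units; within the scatter) are both within the scatter, as is a 1.5-fold higher number from compound 1 to compound 2 (0.18 log units; within the scatter), so compound 3 cannot be separated from either neighbour on this read-out.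

Next in line is compound 4 `CCOC(=O)C1=C(C)N/C(=C/c2cc(C)n(-c3ccc(CN4CCCCC4)cc3)c2C)C1=O`, which differs from compound 3 by (piperidin-1-yl)methyl in place of (trifluoromethyl)sulfanyl on an aromatic carbon. Within the data shown here, the one earlier step that swaps a basic side chain for the (trifluoromethyl)sulfanyl group, a 1.2-fold higher number from compound 1 to compound 3 (0.07 log units; within the scatter), did nothing beyond the scatter, and the exchange of two amine-bearing groups, a 1.5-fold higher number from compound 1 to compound 2 (0.18 log units; within the scatter), was equally flat. Among the measured compounds shown here, nothing measured so far suggests that the group at this position moves the number in this assay. The step of a 1.1-fold lower number from compound 3 to compound 4 (0.03 log units; within the scatter) is therefore expected to stay within the scatter, with no direction favoured. Compound 4 is estimated at 130000 nM in this assay, with a range of 60000 nM to 280000 nM, pending the actual measurement.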

Compound 4, half-maximal effective concentration: 81000 nM
Compound 4: the middle estimate sits 1.6-fold (0.21 log units) above what was measured; the range from low to high includes it.
By their numbers in this assay, from the lowest: compounds 4, 1, 3 and 2 (each within the scatter of the next, the first and the last beyond it).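

In this assay, among these compounds, the step of a 2.2-fold lower number from compound 2 to compound 4 (0.35 log units; beyond the scatter) is the first to pass beyond the scatter, though only modestly, so the group on this aromatic carbon, para to a large group, can separate two compounds after all. The separation is confined to that pair: the same (piperidin-1-yl)methyl group gives a 1.7-fold lower number from compound 3 to compound 4 (0.24 log units; within the scatter) and a 1.5-fold lower number from compound 1 to compound 4 (0.17 log units; within the scatter), so compound 4 cannot be told apart from either compound 1 or compound 3, and the exchange of piperidin-1-yl for dimethylamino on the saturated chain carbon has no readable effect of its own. Among the compounds shown here, no supporting data bear on why the one step passes the scatter while the other two do not.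

On these data alone, it remains open whether the six-membered ring of compound 4 contributes anything specific, which a morpholin-4-ylmethyl or pyrrolidin-1-ylmethyl group at the same place could show. Also open, as far as these compounds go, is whether a longer chain between the aromatic ring and the amine, or a carboxylic acid in place of the amine, would move the number further than the small shift seen here.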